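Swapping the Ketone Group on a Shared Core

The source may report more compounds than this note shows. Statements on the series, on what has been measured and on what is new or still open speak of the compounds shown alone.

Measured compounds:
compound 1 `O=C(/C(=C\c1ccc([N+](=O)[O-])c(O)c1)SCc1ccc(Br)cc1)c1c(F)c(F)c(F)c(F)c1F` gives 10000 nM
compound 2 `O=C(/C(=C\c1ccc([N+](=O)[O-])c(O)c1)SCc1ccc(Br)cc1)c1ccc([N+](=O)[O-])cc1` gives 1000 nM

Both compounds were tested in a functional assay on DU-145 cells (Homo sapiens) for inhibition, read by trypan blue exclusion, with a stated time of 96 h; a lower number here means a stronger inhibitor of growth, a higher number a weaker inhibitor of growth. Within the data shown here, compound 2 has the lowest of the two numbers in this assay, and its only neighbour is compound 1. Among the measured compounds shown here, the single measured step, a 10-fold lower number from compound 1 to compound 2 (1.00 log units; beyond the scatter), shows that changing the group on the carbonyl carbon can move the number well beyond the scatter.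

Compound 3 `O=C(/C(=C\c1ccc([N+](=O)[O-])c(O)c1)SCc1ccc(Br)cc1)C1CCNC1` has not yet been measured. It differs from compound 2 in one place: pyrrolidin-3-yl in place of 4-nitrophenyl on a carbonyl carbon. The step of a 10-fold lower number from compound 1 to compound 2 (1.00 log units; beyond the scatter) bears on this only loosely, since it concerns an exchange of one aromatic ring for another on the same carbonyl carbon and says nothing about a pyrrolidin-3-yl group there. It does show that this position is sensitive, so a shift of similar size in either direction cannot be ruled out. With no closer guide, a step of a 5.0-fold higher number from compound 2 to compound 3 (0.70 log units; beyond the scatter) is expected, towards a weaker inhibitor of growth. Compound 3 is therefore estimated at 5000 nM in this assay, with a range from 1000 nM to 30000 nM.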

Compound 3, concentration for 50% growth inhibition: > 100000 nM
Compound 3 ended at the assay's limit; the forecaster's own chance of this, stated with the estimate: 20%; middle value at least 20-fold (1.30 log units) from the limit.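

For compound 3 the reading is a limit of the assay and not a number: the limit of > 100000 nM in this assay, at which 1 of the 3 values shown sits. Until now this position had shown only one aromatic ring exchanged for another, whereas here a five-membered non-aromatic ring with a hetero atom replaces a six-membered aromatic ring of carbon only, and in this assay the result is an at least 100-fold higher number from compound 2 to compound 3 (2.00 log units; beyond the scatter). The comparison with the pentafluorophenyl compound points the same way, with an at least 10-fold higher number from compound 1 to compound 3 (1.00 log units; beyond the scatter), so both aromatic groups shown on the carbonyl carbon give lower numbers than pyrrolidin-3-yl, and the position tolerates this change far less well than the earlier step suggested.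

Among these compounds, with only one non-aromatic group among the three compounds, the data cannot separate the loss of the aromatic ring from the arrival of the ring nitrogen, since pyrrolidin-3-yl brings both at once. On these data alone, a cyclopentyl group, which has no ring nitrogen, or a phenyl ring carrying an amine would pull those two changes apart, and whether any other non-aromatic group on this carbonyl carbon can keep growth inhibition remains open.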